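This account rests on a few compounds, and the source may have more. Where it says the series, first, only, none or still open, it means among the compounds named here.

Measured in a functional assay on Huh-7 cells (Homo sapiens) for inhibition, read by MTT assay, with a stated time of 72 h; on this read-out higher numbers stand for weaker inhibition and lower numbers for stronger inhibition:
- compound 1 `Nc1ncnc2c1c(-c1cnc3[nH]ccc3c1)nn2CCCCCC(=O)NO`: > 100000 nM
- compound 2 `Nc1nc2cc(-c3nn(CCCCC(=O)NO)c4ncnc(N)c34)ccc2o1`: 9220 nM

The result for compound 1 is a limit of the assay, not a number.

Among the measured compounds shown here, compound 2, at 9220 nM, gives the only numerical value so far.

Compound 3 `Nc1nc2cc(-c3nn(CCCCCCC(=O)NO)c4ncnc(N)c34)ccc2o1` differs from it by a longer chain: 2-(hydroxycarbamoyl)ethyl in place of hydroxycarbamoyl on a saturated chain carbon, four bonds along the chain from an aromatic nitrogen.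

For the measured compounds named here, no measured step shows the effect of this change, so only a moderate move towards stronger inhibition is expected, with wide uncertainty. The expected change is a 3.7-fold lower number from compound 2 to compound 3 (0.57 log units; beyond the scatter).

Compound 3 is estimated at 2500 nM, with an expected range of 400 nM to 15000 nM.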

Compound 3, half-maximal inhibitory concentration: 5710 nM
For compound 3 the middle estimate is 2.3-fold (0.36 log units) below the measured one, and the stated range covers the measured number.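

Among the compounds shown here, on the saturated chain carbon, four bonds along the chain from an aromatic nitrogen, this assay now gives the first readable step: a 1.6-fold lower number from compound 2 to compound 3 (0.21 log units; within the scatter). Placing 2-(hydroxycarbamoyl)ethyl in place of hydroxycarbamoyl therefore leaves the read-out within the usual scatter. Compound 1 differs from both in more than one place, and its result is a limit of the assay, not a number: the limit of > 100000 nM in this assay, at which 1 of the 3 values shown sits.

From the compounds shown here alone, whether a longer chain than that of compound 3 would move the read-out beyond the scatter stays open. So does the effect of a carboxylic acid in place of the hydroxycarbamoyl end.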